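A few compounds are considered here, and "the series" means these few. Any claim that something is new, unique, unknown or untested is made for them only; others in the source may bear on it.

Of the compounds shown here, three sharing one core have been measured in a functional assay on A549 cells (Homo sapiens) for antiproliferative activity, read by MTT assay, with a stated time of 48 h (a lower number here means a stronger inhibitor, a higher number a weaker inhibitor), and they differ only in the aryl group on the carbon of the five-membered ring that carries both ring nitrogen and ring oxygen. There, compound 1 `COc1ccc(-c2nc3cccc(-c4cc(OC)c(OC)c(OC)c4)c3o2)cc1OC`, with 3,4-dimethoxyphenyl, gives 2800 nM, and compound 2 `COc1cc(-c2cccc3nc(-c4ccc(F)cc4)oc23)cc(OC)c1OC`, with 4-fluorophenyl, gives 8700 nM. Compound 3 `COc1cc(-c2cccc3nc(-c4cccc(Cl)c4)oc23)cc(OC)c1OC`, with 3-chlorophenyl, gives only a limit, > 25000 nM, and no number.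

Compound 4 `COc1cc(-c2cccc3nc(-c4ccc5cc[nH]c5c4)oc23)cc(OC)c1OC` has 1H-indol-6-yl in place of 3-chlorophenyl on an aromatic carbon, and the change counts as 1H-indol-6-yl in place of 3-chlorophenyl on an aromatic carbon. Among the measured compounds shown here, no measured compound carries this group, so the expectation rests on how far a change of aryl group alone has moved the number. Going to 4-fluorophenyl gave a 3.1-fold higher number from compound 1 to compound 2 (0.49 log units; beyond the scatter), going to 3-chlorophenyl gave an at least 8.9-fold higher number from compound 1 to compound 3 (0.95 log units; beyond the scatter), and exchanging those two groups gave an at least 2.8-fold higher number from compound 2 to compound 3 (0.45 log units; beyond the scatter). All three steps lie beyond the scatter, and compound 3 sits at the weak end of the series. A replacement of its 3-chlorophenyl therefore has room to move only toward a lower number, probably into the range held by the other two compounds.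

In this assay, the expected change is an at least 6.2-fold lower number from compound 3 to compound 4 (0.79 log units; beyond the scatter). Compound 4 is estimated at 4000 nM, within an expected range of 600 nM to 20000 nM.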

Compound 4, half-maximal inhibitory concentration: 55 nM
Compound 4: the middle estimate sits 73-fold (1.86 log units) above what was measured; measured number outside the range, below it.
By their numbers in this assay, from the lowest: compound 4; then compound 1; then compound 2. At a limit, above all of these: compound 3.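

In this assay, the 1H-indol-6-yl group, the only aryl group of the four with a fused five-membered aromatic ring and a hydrogen-bond donor, gives a 51-fold lower number from compound 1 to compound 4 (1.71 log units; beyond the scatter) and a 160-fold lower number from compound 2 to compound 4 (2.20 log units; beyond the scatter), so the earlier compounds had shown only a small part of what can be reached at this carbon of the shared core. Measured against 3-chlorophenyl, the same change reads as an at least 450-fold lower number from compound 3 to compound 4 (2.65 log units; beyond the scatter), and this figure is only a lower bound on its size. Compound 3 gives a limit and not a number: the limit of > 25000 nM in this assay, at which 1 of the 4 values shown sits.

The compounds shown leave open whether the gain belongs to the hydrogen on the indole nitrogen or to the fused ring system itself, for the two enter together in compound 4. Going by these compounds, an N-methylindolyl or a benzofuranyl group at this carbon would separate the two, and the importance of the point of attachment on the indole also remains open.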